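From 2-ethylphenyl to 3-fluorophenyl on the oxygen

The source may report more compounds than this note shows. Statements on the series, on what has been measured and on what is new or still open speak of the compounds shown alone.

Among the compounds with values here, in a functional assay on MCF7 cells (Homo sapiens) for antiproliferative activity, read by sulforhodamine B assay, with a stated time of 48 h (a higher number here means a weaker inhibitor, a lower number a stronger inhibitor), compound 1 `CCc1ccccc1OS(=O)(=O)c1ccc(N2CCN(C)C2=O)cc1` gives the highest of the three numbers so far (26000 nM). Compound 2 `Cc1ccc(OS(=O)(=O)c2ccc(N3CCN(C)C3=O)cc2)c(C)c1` reads lower (2500 nM), and compound 3 `Cc1cccc(OS(=O)(=O)c2ccc(N3CCN(C)C3=O)cc2)c1` also reads lower (5100 nM). Compound 4 `CN1CCN(c2ccc(S(=O)(=O)Oc3cccc(F)c3)cc2)C1=O` is still unmeasured. It carries 3-fluorophenyl in place of 2-ethylphenyl on an oxygen whose other neighbour is the sulfonyl sulfur (3-fluorophenyl in place of 2-ethylphenyl on an oxygen).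

Within the data shown here, two measured steps bear on this change, and both replace 2-ethylphenyl. The change to 2,4-dimethylphenyl is large (a 10-fold lower number from compound 1 to compound 2 (1.02 log units; beyond the scatter)), and the change to 3-methylphenyl is modest (a 5.1-fold lower number from compound 1 to compound 3 (0.71 log units; beyond the scatter)). These two replacements differ from each other by a modest step (a 2.0-fold higher number from compound 2 to compound 3 (0.31 log units; beyond the scatter)). Among the measured compounds shown here, no measured compound contains fluorine, so the size of the step remains uncertain. Compound 3 serves as the closer guide, with its step (a 5.1-fold lower number from compound 1 to compound 3 (0.71 log units; beyond the scatter)) setting the expected scale. A modest fall is therefore expected in this assay (a 4.3-fold lower number from compound 1 to compound 4 (0.64 log units; beyond the scatter)). For compound 4 the estimate is 6000 nM (expected range 2000 nM to 16000 nM).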

Compound 4, half-maximal inhibitory concentration: > 100000 nM
Compound 4: only a limit was reported (the forecaster's own chance of this, stated with the estimate: 3%); middle value at least 16-fold (1.22 log units) away from the limit.
By their numbers in this assay, from the lowest: compound 2; then compound 3; then compound 1. At a limit, above all of these: compound 4.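

In this assay compound 4 stands at a limit of the assay and not at a number: the limit of > 100000 nM in this assay, at which 1 of the 4 values shown sits.

Within the data shown here, the group on the oxygen whose other neighbour is the sulfonyl sulfur therefore tolerates less than the earlier compounds suggested, since 3-fluorophenyl reads weaker than every aryl group measured before it, with an at least 3.8-fold higher number from compound 1 to compound 4 (0.58 log units; beyond the scatter) and an at least 40-fold higher number from compound 2 to compound 4 (1.60 log units; beyond the scatter). The clearest single exchange is fluoro in place of methyl on an aromatic carbon, with an at least 19-fold higher number from compound 3 to compound 4 (1.29 log units; beyond the scatter), so this one change separates a measurable compound from one at the limit.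

Going by these compounds, whether this drop belongs to fluoro itself or to the loss of methyl remains open, and a chloro or methoxy group in place of the fluoro would bear on that. On these data alone, how far compound 4 lies past its limit also remains open.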